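The compounds below may be only part of what the source reports. "The series", "measured", "known", "first", "only" and "open" are said of these compounds alone.

Measured so far:
compound 1 `COc1ccc(Cc2nnc(CN(c3cccc(Cl)c3C)S(=O)(=O)c3ccc(C)cc3)o2)cc1` — in a functional assay on CHO cells for antagonist activity at prostaglandin E2 receptor EP1 subtype (Homo sapiens), read by FLIPR and calcium flux (on this read-out lower numbers stand for stronger inhibition and higher numbers for weaker inhibition), compound 1 gives 39.8 nM
compound 2 `Cc1ccc(S(=O)(=O)N(Cc2nnc(Cc3ccc(C(F)(F)F)cc3)o2)c2cccc(Cl)c2C)cc1` — in this assay compound 2 gives 158 nM

Compound 2 stands at the highest of the two numbers seen so far; its nearest neighbour is compound 1, and the step of a 4.0-fold higher number from compound 1 to compound 2 (0.60 log units; beyond the scatter) separates them, which is beyond the usual scatter of this measurement.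

Compound 3 `Cc1ccc(S(=O)(=O)N(Cc2nnc(Cc3ccc(F)cc3)o2)c2cccc(Cl)c2C)cc1` has not yet been measured. It differs from compound 2 in one place: fluoro in place of trifluoromethyl on an aromatic carbon. For the measured compounds named here, the only measured step that touches this position is a 4.0-fold higher number from compound 1 to compound 2 (0.60 log units; beyond the scatter), where the trifluoromethyl group replaced a methoxy group; putting a single fluorine there instead has no direct precedent among the measured compounds. A small change back toward lower numbers is expected, with a 2.0-fold lower number from compound 2 to compound 3 (0.30 log units; within the scatter) as the estimated step. Compound 3 is therefore expected to give about 80 nM, within a range from 30 nM to 250 nM.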

Compound 3, inhibition constant: 501 nM
The estimate for compound 3 lay 6.3-fold (0.80 log units) below the measured number; measured number above the stated range.
By their numbers in this assay, from the lowest: compound 1; then compound 2; then compound 3.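

Replacing trifluoromethyl with fluoro on this aromatic ring does not bring the number back down: the change gives a 3.2-fold higher number from compound 2 to compound 3 (0.50 log units; beyond the scatter) in this assay. Removing heavy atoms at this position therefore does not by itself recover the stronger inhibition of the methoxy compound, and the widest gap so far is a 13-fold higher number from compound 1 to compound 3 (1.10 log units; beyond the scatter), so the choice of group at this one position clearly matters, with methoxy giving the lowest number of the three. Nothing available here explains why these groups rank in this order.

The compounds shown leave open whether another group at this position, such as an amine, a hydroxyl or a longer ether chain, could match or improve on methoxy. They also leave open whether the same ranking would hold with changes elsewhere on the shared core.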